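From Chloro to Cyano on the Shared Core

The source may report more compounds than this note shows. Statements on the series, on what has been measured and on what is new or still open speak of the compounds shown alone.

Three compounds share one core and differ in a single group on it. Compound 1, `FC(F)(F)c1ccc2c(c1)nc(-c1cccnc1)n2C1CC1`, carries a trifluoromethyl group. In an assay on V79 cells for inhibition of cytochrome P450 11B1, mitochondrial (Homo sapiens), read by HTRF, with a stated time of 1 h (a lower number here means a stronger inhibitor, a higher number a weaker inhibitor), compound 1 gives > 10000 nM, which is a limit of the assay and not a number. Compound 2, `Clc1ccc2nc(-c3cccnc3)n(C3CC3)c2c1`, carries chloro instead, and in this assay compound 2 gives 477 nM. Among the measured compounds shown here, that is the only true number in the set; the other value shown is the limit of > 10000 nM in this assay, at which 1 of the 2 values shown sits. Compound 3, `N#Cc1ccc2nc(-c3cccnc3)n(C3CC3)c2c1`, has not been measured yet and differs from compound 2 by cyano in place of chloro on an aromatic carbon. For the measured compounds named here, no measured pair shows how this swap moves the readout, so a step within the usual scatter is expected, the expected step being a 1.6-fold lower number from compound 2 to compound 3 (0.20 log units; within the scatter). Compound 3 is therefore estimated at 300 nM, with a range from 80 nM to 1200 nM.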

Compound 3, half-maximal inhibitory concentration: 374 nM
Compound 3: middle estimate off by 1.2-fold (0.10 log units), on the low side, and the stated range covers the measured number.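

On this aromatic carbon, cyano in place of chloro gives a 1.3-fold lower number from compound 2 to compound 3 (0.11 log units; within the scatter), so this assay does not separate the two groups, even though cyano counts a hydrogen-bond acceptor and chloro does not. Among the compounds shown here, compound 2 and compound 3 are the first pair on the shared core with a step that can be read, as both give true numbers and not a limit of the assay. Nothing measured here explains why these two groups read alike.

For the compounds shown here, with only this one swap at this position, it remains open how an amine, a carboxylic acid or a longer chain on the same carbon would read. On these data alone, it also remains open whether cyano and chloro would still read alike with a different group in place of the cyclopropyl ring.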